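Moving the chlorine from one ring position to another

A few compounds are considered here, and "the series" means these few. Any claim that something is new, unique, unknown or untested is made for them only; others in the source may bear on it.

Compound 1 `Oc1cccc(-c2cc(-c3ccncc3)nc(-c3ccccc3Cl)c2)c1` is the starting point of this step, yet in a functional assay on HCT-15 cells (Homo sapiens) for cytotoxicity, read by CCK-8 assay and cell counting, with a stated time of 2 days (on this read-out higher numbers stand for weaker inhibition and lower numbers for stronger inhibition), compound 1 gives "not determined" (no result reported), so it cannot be placed on the numbers. Two neighbours were measured. Compound 2 `Oc1cccc(-c2cc(-c3ccsc3)nc(-c3ccccc3Cl)c2)c1` gives 2500 nM in this assay. Compound 3 `Oc1cccc(-c2cc(-c3ccccc3)nc(-c3ccccc3Cl)c2)c1` gives 2930 nM. The step of a 1.2-fold higher number from compound 2 to compound 3 (0.07 log units; within the scatter) shows that exchanging the five-membered ring for a phenyl leaves the result essentially unchanged.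

Compound 4 `Oc1cccc(-c2cc(-c3ccncc3)nc(-c3ccc(Cl)cc3)c2)c1` differs from compound 1 as follows: 4-chlorophenyl in place of 2-chlorophenyl on an aromatic carbon. No measured step touches the chlorophenyl group, so the one step shown does not bear directly on this change; it only tells that the measured compounds sit close together. With compound 1 unmeasured, there is no direction to build on. Among the measured compounds shown here, the only guide is compound 2 at 2500 nM and compound 3 at 2930 nM. Compound 4 is therefore expected to fall in that same region, estimated at 2800 nM, within a range from 1000 nM to 8000 nM.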

Compound 4, half-maximal inhibitory concentration: 2630 nM
The estimate for compound 4 lay 1.1-fold (0.03 log units) above the measured number; low and high end bracket the measured number.
By their numbers in this assay, from the lowest: compounds 2, 4 and 3 (each within the scatter of the next).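

In this assay compound 1 gives "not determined" (no result reported) and so the swap of 2-chlorophenyl for 4-chlorophenyl in compound 4 cannot be read as a step. Going by these compounds, what moving the chlorine does to the number therefore stays open. No information on a possible cause is available here.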